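Butyl sulfonamide in place of dichlorophenyl at the sulfonyl

A few compounds are considered here, and "the series" means these few. Any claim that something is new, unique, unknown or untested is made for them only; others in the source may bear on it.

Measured compounds:
compound 1 `Cc1ccc(S(=O)(=O)N2CCN(C[C@H](C)Nc3ncnc4c(C)csc34)CC2)cc1` gives 170 nM in a functional assay on RH7777 cells for antagonist activity at lysophosphatidic acid receptor 2 (Homo sapiens), read by calcium flux; on this read-out lower numbers stand for stronger inhibition and higher numbers for weaker inhibition
compound 2 `Cc1csc2c(N[C@@H](C)CN3CCN(S(=O)(=O)c4ccc(Cl)c(Cl)c4)CC3)ncnc12` gives 17 nM in this assay
compound 3 `COc1ccccc1N1CCN(CC(C)(C)Nc2nc(C(F)(F)F)nc3ccccc23)CC1` gives > 30000 nM in this assay, which is a limit of the assay and not a number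

Among the measured compounds shown here, compound 2 holds the lowest of the two numbers in this assay; the only measured step, a 10-fold lower number from compound 1 to compound 2 (1.00 log units; beyond the scatter), shows how much the group on the sulfonyl sulfur matters. Compound 4 `CCCCS(=O)(=O)N1CCN(C[C@H](C)Nc2ncnc3c(C)csc23)CC1` is not yet measured; it differs from compound 2 by butyl in place of 3,4-dichlorophenyl on a sulfonyl sulfur. For the measured compounds named here, no measured step covers a chain in this place, and the one step available points to a sensitive position, so a rise is expected. Compound 4 is estimated at 600 nM, between 100 nM and 5000 nM, an expected step of a 35-fold higher number from compound 2 to compound 4 (1.55 log units; beyond the scatter).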

Compound 4, half-maximal inhibitory concentration: 6610 nM
Compound 4: middle estimate off by 11-fold (1.04 log units), on the low side, and the stated range ends below it.
By their numbers in this assay, from the lowest: compound 2; then compound 1; then compound 4. At a limit, above all of these: compound 3.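

In this assay, butyl on the sulfonyl sulfur gives up far more than either phenyl group does: a 390-fold higher number from compound 2 to compound 4 (2.59 log units; beyond the scatter), and a 39-fold higher number from compound 1 to compound 4 (1.59 log units; beyond the scatter). Both steps are larger than the one between the two phenyl groups, a 10-fold lower number from compound 1 to compound 2 (1.00 log units; beyond the scatter), so among these compounds the choice between ring and chain at this position weighs more than the choice of ring substituents. Nothing at hand accounts for the size of these steps. Going by these compounds, whether a pyridine ring, a benzyl group or a cyclohexyl ring on the sulfonyl sulfur would hold the low number of compound 2 remains open.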